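Amide-nitrogen replacement in a series without readable potency

The source may hold more compounds than are shown below. What is called first, only, known or untested is meant among the compounds shown, and "the series" means these compounds.

Measured so far:
compound 1 `CCN(CC)C(=O)COc1ccc2cc(C(O)(C(F)(F)F)C(F)(F)F)c(O)cc2c1` — in an assay on isolated protein for inhibition of tyrosine-protein phosphatase non-receptor type 13 (Homo sapiens), read by spectrophotometry (on this read-out lower numbers stand for stronger inhibition and higher numbers for weaker inhibition), compound 1 gives > 20000 nM, a limit of the assay.
compound 2 `COc1ccc(CNC(=O)COc2ccc3cc(C(O)(C(F)(F)F)C(F)(F)F)c(O)cc3c2)cc1OC` — in this assay compound 2 gives > 20000 nM, a limit of the assay.

Compound 2 stands at the limit of this assay, and both values shown sit at that same limit (the limit of > 20000 nM in this assay, at which 2 of the 2 values shown sit). The step that the two limits leave unreadable from compound 1 to compound 2 cannot be read because the step that the two limits leave unreadable from compound 1 to compound 2 runs between two limits.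

Compound 3 `Cc1ccc(S(=O)(=O)NNC(=O)COc2ccc3cc(C(O)(C(F)(F)F)C(F)(F)F)c(O)cc3c2)cc1` differs from compound 2 by ((4-methylphenyl)sulfonyl)amino in place of 3,4-dimethoxybenzyl on an amide-type nitrogen. Going by the values given here, only one measured step exists, and it is unreadable, so no measured step bears on this change. The expectation for compound 3 rests on the two limits alone: compound 3 is expected to remain at the limit of this assay. The step from compound 2 to compound 3 is estimated as a step that the limit leaves unreadable from compound 2 to compound 3, none beyond the scatter. The estimate for compound 3 in this assay is 40000 nM, with a range from 12000 nM to 150000 nM.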

Compound 3, half-maximal inhibitory concentration: 14900 nM
For compound 3 the middle estimate is 2.7-fold (0.43 log units) above the measured one, within the range that was stated.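

In this assay, going by these compounds alone, compound 3 gives 14900 nM, the only value shown that is a number and not a limit of the assay. On the amide-type nitrogen, ((4-methylphenyl)sulfonyl)amino in place of 3,4-dimethoxybenzyl gives an at least 1.3-fold lower number from compound 2 to compound 3 (0.12 log units; that floor lies within the scatter), and on the carbonyl carbon, (((4-methylphenyl)sulfonyl)amino)amino in place of diethylamino gives an at least 1.3-fold lower number from compound 1 to compound 3 (0.12 log units; that floor lies within the scatter). Neither floor separates compound 3 from compound 1 or compound 2, whose values remain limits of the assay: the limit of > 20000 nM in this assay, at which 2 of the 3 values shown sit.

From the compounds shown here alone, the true distance of compound 1 and compound 2 from compound 3 stays unknown, and the step between compound 1 and compound 2 cannot be read. Also open, going by these compounds, is whether a carboxylic acid or a primary amine on the same carbonyl carbon would give a number in this assay.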